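A terminal amine swap and its expected solubility

The source may hold more compounds than are shown below. What is called first, only, known or untested is meant among the compounds shown, and "the series" means these compounds.

Compound 1 (`Cc1ccccc1C(=O)Nc1ccc(C(=O)N2CCCC(NCCCc3ccncc3)c3cc(Cl)ccc32)c(C)c1`) gives 2.3 ug/mL in a physicochemical assay for solubility, measured as thermodynamic solubility, with a stated time of 24 h; on this read-out lower numbers stand for lower solubility and higher numbers for higher solubility. Compound 2 (`Cc1ccccc1C(=O)Nc1ccc(C(=O)N2CCCC(NCCC(=O)N3CCOCC3)c3cc(Cl)ccc32)c(C)c1`) gives 2.3 ug/mL in this assay. Compound 3 (`Cc1ccccc1C(=O)Nc1ccc(C(=O)N2CCCC(NCCCN3CCN(C)CC3)c3cc(Cl)ccc32)c(C)c1`) gives 2.3 ug/mL in this assay.

Compound 3 therefore stands level with compounds 1 and 2: all three share the same value to the digits shown. The three compounds differ only at the far end of the chain that hangs from the amine nitrogen, and each of the three exchanges left the number where it was: no change at the digits printed from compound 1 to compound 2 (within the scatter), no change at the digits printed from compound 1 to compound 3 (within the scatter) and no change at the digits printed from compound 2 to compound 3 (within the scatter).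

Compound 4 (`CCN(CC)CCCNC1CCCN(C(=O)c2ccc(NC(=O)c3ccccc3C)cc2C)c2ccc(Cl)cc21`) continues this series of end-of-chain exchanges. The change from compound 3 is diethylamino in place of 4-methylpiperazin-1-yl on a saturated chain carbon, three bonds along the chain from an amine nitrogen. Every measured step at this position, whether it moved between a ring and a chain or between one ring and another, stayed within the scatter, so the same is expected here: no step beyond the scatter, in either direction, is expected from compound 3 to compound 4, that is no change at the digits printed from compound 3 to compound 4 (within the scatter). Compound 4 is thus estimated to give 2.3 ug/mL in this assay, with a plausible range from 1.2 ug/mL to 4.6 ug/mL.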

Compound 4, solubility: 2.3 ug/mL
Compound 4: middle estimate and measured number agree at the digits printed; the measured number falls inside the stated range.
By their numbers in this assay, from the lowest: compounds 1, 2, 3 and 4 (each within the scatter of the next).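

Compound 4 is the only one of the four whose chain end holds no ring: its diethylamino group has 5 heavy atoms and 1 nitrogen, whereas the 4-methylpiperazin-1-yl group it replaces has 7 heavy atoms and 2 nitrogens in a six-membered ring. In this assay, an open-chain end group therefore reads like the ringed ones, with no change at the digits printed from compound 3 to compound 4 (within the scatter), no change at the digits printed from compound 2 to compound 4 (within the scatter) and no change at the digits printed from compound 1 to compound 4 (within the scatter), so within these four compounds neither the ring nor the extra atoms show up in the number. No measurement shown gives a reason for these readings.

Going by these compounds, all four compounds end in a nitrogen-containing group, so it remains open whether a carboxylic acid or a hydroxyl at the end of the chain would step beyond the scatter. On these data alone, a longer chain than the 3-(diethylamino)propyl of compound 4 and changes to the shared core are also open, as every compound here keeps that core.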